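Selenocyanate chain length and linker in a quinazoline series

The compounds below may be only part of what the source reports. "The series", "measured", "known", "first", "only" and "open" are said of these compounds alone.

Measured in a functional assay on MDA-MB-231 cells (Homo sapiens) for inhibition, read by MTT assay, with a stated time of 48 h; a lower number here means a stronger inhibitor, a higher number a weaker inhibitor:
compound 1 `COc1ccc(N(C)c2nc(C)nc3ccccc23)cc1C(=O)OCCCC[Se]C#N` gives 554 nM;
compound 2 `COc1ccc(N(C)c2nc(C)nc3ccccc23)cc1OCC[Se]C#N` gives 13 nM;
compound 3 `COc1ccc(N(C)c2nc(C)nc3ccccc23)cc1OCCCC[Se]C#N` gives 1350 nM.

The three compounds share one core, and the two cores of compound 2 and compound 1 differ as follows: a group of 10 heavy atoms (6 carbon, 1 nitrogen, 2 oxygen, 1 selenium; no ring) in place of a group of 6 heavy atoms (3 carbon, 1 nitrogen, 1 oxygen, 1 selenium; no ring), on an aromatic carbon. That difference brings a 43-fold lower number from compound 1 to compound 2 (1.63 log units; beyond the scatter). Within the ether series, lengthening the chain, (a group of 5 heavy atoms (3 carbon, 1 nitrogen, 1 selenium; no ring) in place of a group of 3 heavy atoms (1 carbon, 1 nitrogen, 1 selenium; no ring), on a saturated chain carbon, two bonds along the chain from an oxygen on an aromatic ring), gives a 100-fold higher number from compound 2 to compound 3 (2.02 log units; beyond the scatter). Compound 1 and compound 3 stand closer together: a 2.4-fold higher number from compound 1 to compound 3 (0.39 log units; beyond the scatter).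

Compound 4 `COc1ccc(N(C)c2nc(C)nc3ccccc23)cc1C(=O)OCCCCCC[Se]C#N` is not yet measured. It differs from compound 1 by a group of 5 heavy atoms (3 carbon, 1 nitrogen, 1 selenium; no ring) in place of a group of 3 heavy atoms (1 carbon, 1 nitrogen, 1 selenium; no ring), on a saturated chain carbon, four bonds along the chain from an oxygen next to a carbonyl group. This is the same kind of change as that from compound 2 to compound 3, but the place differs: there the added carbons sat two bonds along the chain from an oxygen on an aromatic ring, here they sit four bonds along the chain from an oxygen next to a carbonyl group. For compound 4 a weakening step is expected because the same kind of change gave a 100-fold higher number from compound 2 to compound 3 (2.02 log units; beyond the scatter). A smaller step, estimated at a 4.0-fold higher number from compound 1 to compound 4 (0.60 log units; beyond the scatter), is expected for compound 4 since compound 1 already starts at 554 nM. Compound 4 is estimated at 2200 nM, expected between 700 nM and 8000 nM.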

Compound 4, half-maximal inhibitory concentration: 2210 nM
For compound 4 the middle estimate is 1.0-fold (0.00 log units) below the measured one; low and high end bracket the measured number.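

In this assay, lengthening the chain on the ester linker brings a 4.0-fold higher number from compound 1 to compound 4 (0.60 log units; beyond the scatter), so the change weakens the compounds in both pairs and its direction carries over from the ether to the ester. Its size does not carry over, and the two steps stand clearly apart: the same change on two cores in this assay, a 100-fold higher number (2.02 log units; beyond the scatter) from compound 2 to compound 3 and a 4.0-fold higher number (0.60 log units; beyond the scatter) from compound 1 to compound 4, 26-fold (1.42 log units) apart, beyond the scatter of two such steps This does not show what sets the size of the step, as the two pairs differ both in the linker and in the chain length they start from, and two pairs give no rule for any further core.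

Compound 2 gives 13 nM. As far as these compounds go, it remains open whether a shorter chain on the ester, matching that of compound 2, would give a similar number, and so whether the large step belongs to the ether linker or to that shortest chain. From the compounds shown here alone, how a longer chain on the ether, or an amide in place of the ester, would behave also remains open.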